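Dimethylcarbamoyl in place of acetyl on the shared core

This account rests on a few compounds, and the source may have more. Where it says the series, first, only, none or still open, it means among the compounds named here.

Measured so far, in a toxicity assay on NIH3T3 cells (Mus musculus) for cytotoxicity, read by resazurin assay; a lower number here means that less compound is needed, a higher number that more compound is needed for the effect:
Compound 1, `CC(C)OC(=O)c1ccc(NCc2cncn2Cc2ccc(-c3ccccc3)cc2)cc1-c1ccccc1`, gives only the limit > 10000 nM.
Compound 2, `c1ccc(-c2ccc(Cn3cncc3CNc3ccc(-c4cc5ccccc5o4)c(-c4ccccc4)c3)cc2)cc1`, gives only the limit > 10000 nM.
Compound 3, `CC(=O)c1ccc(NCc2cncn2Cc2ccc(-c3ccccc3)cc2)cc1-c1ccccc1`, gives only the limit > 10000 nM.

All three measured values sit at the same limit, (the limit of > 10000 nM in this assay, at which 3 of the 3 values shown sit), so no ordering among the three can be drawn. Every step within the series is therefore unreadable: a step that the two limits leave unreadable from compound 1 to compound 2, a step that the two limits leave unreadable from compound 1 to compound 3 and a step that the two limits leave unreadable from compound 2 to compound 3. Compound 3 stands at the limit alongside the other two; its place on the numbers is known only as a boundary, not as a value.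

Compound 4, `CN(C)C(=O)c1ccc(NCc2cncn2Cc2ccc(-c3ccccc3)cc2)cc1-c1ccccc1`, differs from compound 3 by dimethylamino in place of methyl on a carbonyl carbon. The change sits on the carbonyl carbon that also carries the variation in the measured steps, yet none of those steps bears readably on it, because all values rest at the limit of > 10000 nM in this assay, at which 3 of the 3 values shown sit. No readable step at this position is available, and nothing in the series points toward a value that would fall inside the measured range.

The step from compound 3 to compound 4 in this assay is expected as a step that the limit leaves unreadable from compound 3 to compound 4, which is to say no readable step. Compound 4 is expected at 20000 nM, within 10000 nM to 60000 nM, most likely again reported only as the limit.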

Compound 4, half-maximal effective concentration: > 1000 nM
Compound 4 gave a limit, no number; the forecaster's own chance of this, stated with the estimate: 85%; the middle value is on the limit's open side.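

In this assay compound 4 gives > 1000 nM, a limit and not a number. For the compounds shown here, compound 1, compound 2 and compound 3 also stand only as limits, so no step from any of them to compound 4 can be read. The compounds shown leave open where any of these four compounds would fall as an actual number in this assay.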